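A Cyclopropyl Swap on a Chemokine Receptor Antagonist

A few compounds are considered here, and "the series" means these few. Any claim that something is new, unique, unknown or untested is made for them only; others in the source may bear on it.

Of the compounds shown here, two have been measured in a functional assay on U2OS cells for antagonist activity at C-X-C chemokine receptor type 3 (Homo sapiens), read by beta-arrestin recruitment; a higher number here means a weaker inhibitor, a lower number a stronger inhibitor. Compound 1, `CC[C@@H]1CN(c2scnc2-c2nc3ccccc3[nH]2)CCN1C(=O)Cn1cnc2cccnc21`, gives 604 nM in this assay. Compound 2, `Cc1nc(-c2nc3ccccc3[nH]2)c(N2CCN(C(=O)Cn3cnc4cccnc43)[C@H](C)C2)s1`, gives 1050 nM in this assay. The two numbers sit within the usual scatter of each other, so compound 2 cannot be told apart from compound 1 on these data.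

Compound 3, `C[C@@H]1CN(c2sc(C3CC3)nc2-c2nc3ccccc3[nH]2)CCN1C(=O)Cn1cnc2cccnc21`, has not yet been measured. It differs from compound 2 in one place: cyclopropyl in place of methyl on an aromatic carbon. For the measured compounds named here, no measured pair in this set shows what such a swap does, so the expectation rests on the single change alone. A small group grows into a somewhat larger one at the same spot, and the step is expected to stay within the scatter, in either direction. The expected step of a 1.3-fold lower number from compound 2 to compound 3 (0.12 log units; within the scatter) is therefore estimated as no change beyond the scatter. Compound 3 is expected to give about 800 nM, with a likely range from 300 nM to 2500 nM.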

Compound 3, half-maximal inhibitory concentration: 745 nM
Compound 3: middle estimate off by 1.1-fold (0.03 log units), on the high side; the range from low to high includes it.
By their numbers in this assay, from the lowest: compounds 1, 3 and 2 (each within the scatter of the next).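

Cyclopropyl in place of methyl on this aromatic carbon, next to the ring nitrogen and next to the ring sulfur, gives a 1.4-fold lower number from compound 2 to compound 3 (0.15 log units; within the scatter) in this assay. This position therefore carries the larger cyclopropyl group as well as methyl, with no change that can be told apart from the differences seen between repeated measurements. No supporting measurement bears on why the two groups give matching results.

Both groups are made of carbon and hydrogen alone, so the compounds shown leave open what an amine or a carboxylic acid would do at this position. They also leave open whether a longer chain, such as n-butyl, or a bigger ring, such as phenyl, would still fit there without a step beyond the scatter.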